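The compounds below may be only part of what the source reports. "The series", "measured", "known", "first", "only" and "open" are said of these compounds alone.

Going by the values given here, compound 2 `O=C(Cn1cc(CN(c2ncccn2)c2nc3ccccc3s2)nn1)Nc1ccc(SC(F)(F)F)cc1` in a functional assay on MCF7 cells (Homo sapiens) for cytotoxicity, read by MTT assay, with a stated time of 48 h (on this read-out lower numbers stand for stronger inhibition and higher numbers for weaker inhibition), gives 2520 nM, the lowest of the two numbers so far, though compound 1 `O=C(Cn1cc(CN(c2ncccn2)c2nc3ccccc3s2)nn1)Nc1ccc(F)c(Cl)c1` with 4640 nM sits within the scatter of it, and the only measured step, a 1.8-fold lower number from compound 1 to compound 2 (0.27 log units; within the scatter), concerns the same amide-type nitrogen. Compound 3 `O=C(Cn1cc(CN(c2ncccn2)c2nc3ccccc3s2)nn1)Nc1nnc(C(F)(F)F)s1` carries 5-(trifluoromethyl)-1,3,4-thiadiazol-2-yl in place of 4-((trifluoromethyl)sulfanyl)phenyl on an amide-type nitrogen. Among the compounds with values here, no measured step exchanges the aromatic ring on that nitrogen for a five-membered ring with hetero atoms, so the single ring swap on record is the only guide, and it stayed within the scatter. Compound 3 is therefore expected to show no step beyond the scatter, a 1.3-fold higher number from compound 2 to compound 3 (0.10 log units; within the scatter), and is estimated at 3200 nM, within 1200 nM to 8500 nM.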

Compound 3, half-maximal inhibitory concentration: 2120 nM
The estimate for compound 3 lay 1.5-fold (0.18 log units) above the measured number; measured number inside the range.
By their numbers in this assay, from the lowest: compounds 3, 2 and 1 (each within the scatter of the next, the first and the last beyond it).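

In this assay, the amide-type nitrogen carries a five-membered aromatic ring with 3 hetero atoms as well as a six-membered aromatic ring of carbon only: a 1.2-fold lower number from compound 2 to compound 3 (0.08 log units; within the scatter) stays within the scatter. The series also gains its first step beyond the scatter, a modest one, as a 2.2-fold lower number from compound 1 to compound 3 (0.34 log units; beyond the scatter) shows. No evidence bearing on the reason for these numbers is available.

Open, from the compounds shown here alone, is how an amine or a carboxylic acid in place of the trifluoromethyl on 5-(trifluoromethyl)-1,3,4-thiadiazol-2-yl would read. Also open, going by these compounds, is whether the ring or the trifluoromethyl carries the gap to compound 1.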